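Spirocyclic Amine in Place of Fluorophenoxy: Solubility Outlook

The source may hold more compounds than are shown below. What is called first, only, known or untested is meant among the compounds shown, and "the series" means these compounds.

The measured compounds and their values:
Compound 1, `COc1ccc2[nH]c(C(=O)N3CC(=O)N(Cc4ccccc4)[C@@H](CN4CCCCC4)C3)cc2c1`: in a physicochemical assay for solubility, read by spectrophotometry, in phosphate buffer, with a stated time of 2 h, at pH 7.4 (on this read-out higher numbers stand for higher solubility and lower numbers for lower solubility), compound 1 gives > 25000 nM, a limit of the assay rather than a number.
Compound 2, `COc1ccc2[nH]c(C(=O)N3CC(=O)N(Cc4ccccc4)[C@@H](COC(C)(C)C)C3)cc2c1`: in this assay compound 2 gives 65500 nM.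
Compound 3, `COc1ccc2[nH]c(C(=O)N3CC(=O)N(Cc4ccccc4)[C@@H](COc4ccc(F)cc4)C3)cc2c1`: in this assay compound 3 gives 17500 nM.

Compound 3 stands at the lowest of the two numbers shown, with compound 2 as its nearest neighbour through a 3.7-fold lower number from compound 2 to compound 3 (0.57 log units; beyond the scatter). The step from compound 1 sits at an at least 1.4-fold lower number from compound 1 to compound 3 (0.15 log units; that floor lies within the scatter), and the limit of > 25000 nM in this assay, at which 1 of the 3 values shown sits, keeps its size from being read. Compound 4, `COc1ccc2[nH]c(C(=O)N3CC(=O)N(Cc4ccccc4)[C@@H](CN4CCC5(CCCC5)CC4)C3)cc2c1`, differs from compound 3 in one place: a group of 10 heavy atoms (9 carbon, 1 nitrogen; one five-membered non-aromatic ring of carbon only, one six-membered non-aromatic ring with 1 hetero atom) in place of a group of 8 heavy atoms (6 carbon, 1 oxygen, 1 fluorine; one six-membered aromatic ring of carbon only), on a saturated chain carbon bound to a saturated ring carbon. Among the measured compounds shown here, the step that bears on this is the one from compound 1, which carries piperidin-1-yl at the same place, to compound 3; the step from compound 1 to compound 2 is left unreadable by the limit. Since compound 1 reached only a limit, compound 4 is expected to move back upward, by about a 2.3-fold higher number from compound 3 to compound 4 (0.36 log units; beyond the scatter). Compound 4 is therefore estimated at 40000 nM, within 12000 nM to 150000 nM, with a fair chance that the assay again reports only a limit.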

Compound 4, solubility: 5000 nM
The estimate for compound 4 lay 8.0-fold (0.90 log units) above the measured number; the whole stated range lies above it.
By their numbers in this assay, from the lowest: compound 4; then compound 3; then compound 2.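

In this assay the spirocyclic amine brings the number to the lowest yet seen on this saturated chain carbon, with a 3.5-fold lower number from compound 3 to compound 4 (0.54 log units; beyond the scatter) and a 13-fold lower number from compound 2 to compound 4 (1.12 log units; beyond the scatter) on record. With an at least 5.0-fold lower number from compound 1 to compound 4 (0.69 log units; beyond the scatter) for the swap from piperidin-1-yl, the series now shows that a ring amine at this place does not by itself keep the number high, and that two amines can lie well apart. That last step is only a floor, as compound 1 stands at a limit of the assay and not at a number: the limit of > 25000 nM in this assay, at which 1 of the 4 values shown sits.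

The compounds shown leave open whether the fall goes with the added five-membered carbon ring or with the larger group as a whole. They also leave open how a pyrrolidine, a morpholine or a carboxylic acid on the chain would read here.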